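Pyrrolidin-1-yl for Cyclopentyl on a Sulfonyl Sulfur

This account rests on a few compounds, and the source may have more. Where it says the series, first, only, none or still open, it means among the compounds named here.

In an ADME assay on the whole organism (plasma) for pharmacokinetics, with Rattus norvegicus as the target (on this read-out higher numbers stand for fast clearance and lower numbers for slow clearance), compound 2 `O=S(=O)(c1cc(F)c(O)c2ncccc12)C1CCCC1` gives 0.62 mL/min/kg, the second highest of three numbers. Compound 1 `O=S(=O)(c1ccc(F)cc1)c1cc(F)c(O)c2ncccc12` stands higher at 12 mL/min/kg, and compound 3 `O=S(=O)(c1cc(Cl)c(O)c2ncccc12)C1CCCC1` stands lower at 0.3 mL/min/kg. Compound 4 `O=S(=O)(c1cc(F)c(O)c2ncccc12)N1CCCC1` has not yet been measured. It carries pyrrolidin-1-yl in place of cyclopentyl on a sulfonyl sulfur. Going by the values given here, the closest precedent is the large step of a 19-fold lower number from compound 1 to compound 2 (1.29 log units; beyond the scatter), which changed the same place but involved a different group. The modest step of a 2.1-fold lower number from compound 2 to compound 3 (0.32 log units; beyond the scatter) changed an aromatic carbon instead. Neither measures this swap directly, so only a small rise is expected, an estimated 1.9-fold higher number from compound 2 to compound 4 (0.29 log units; within the scatter). For compound 4 the expected value is 1.2 mL/min/kg, with an estimated range of 0.4 mL/min/kg to 4 mL/min/kg.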

Compound 4, clearance: 11 mL/min/kg
Beside the measured number, compound 4's estimate is 9.2-fold (0.96 log units) below it, outside the stated range (above it).
By their numbers in this assay, from the lowest: compound 3; then compound 2; then compounds 4 and 1 (each within the scatter of the next).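

In this assay the swap at the sulfonyl sulfur keeps the ring size and heavy-atom count, yet a single ring nitrogen gives an 18-fold higher number from compound 2 to compound 4 (1.25 log units; beyond the scatter) and so removes nearly all the advantage cyclopentyl had shown. Going by these compounds alone, with a 1.1-fold lower number from compound 1 to compound 4 (0.04 log units; within the scatter) pyrrolidin-1-yl and 4-fluorophenyl cannot be told apart, which leaves cyclopentyl as the only one of these three groups giving a low number on the shared core. Nothing available here explains this result. Still open, as far as these compounds go, is whether morpholin-4-yl or dimethylamino on the sulfonyl sulfur would behave like pyrrolidin-1-yl. Also open, from the compounds shown here alone, is whether chloro in place of fluoro would lower the number with pyrrolidin-1-yl as it did with cyclopentyl.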